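The compounds below may be only part of what the source reports. "The series", "measured", "known", "first", "only" and "open" are said of these compounds alone.

In a functional assay on HepG2 cells (Homo sapiens) for cytotoxicity, read by MTT assay, with a stated time of 48 h (on this read-out higher numbers stand for weaker inhibition and lower numbers for stronger inhibition), compound 1 (`O=C1CS/C(=N/c2ccccc2)N1Cc1ccncc1`) gives 26000 nM, compound 2 (`O=C1/C(=C\c2ccc(O)cc2)S/C(=N/c2ccccc2)N1Cc1ccncc1`) gives 11800 nM and compound 3 (`COc1ccc(/C=C2/S/C(=N/c3ccccc3)N(Cc3ccncc3)C2=O)cc1`) gives 19100 nM. Compound 3 thus stands within the scatter of both other compounds. Compound 4 (`O=C1/C(=C\c2ccc(O)c(O)c2)S/C(=N/c2ccccc2)N1Cc1ccncc1`) has not yet been measured and differs from compound 3 as follows: 3,4-dihydroxyphenyl in place of 4-methoxyphenyl on a double-bonded chain carbon bound to a double-bonded ring carbon. For the measured compounds named here, the one measured step that bears on this change is a 1.6-fold higher number from compound 2 to compound 3 (0.21 log units; within the scatter). That step, methyl in place of hydrogen on an oxygen on an aromatic ring, stays within the scatter, so no step beyond the scatter is expected in this assay. The expected change is a 1.5-fold lower number from compound 3 to compound 4 (0.17 log units; within the scatter), with only a slight lean towards a lower number. Compound 4 is estimated at 13000 nM, with an expected range of 6000 nM to 27000 nM.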

Compound 4, half-maximal inhibitory concentration: 16200 nM
For compound 4 the middle estimate is 1.2-fold (0.10 log units) below the measured one; the measured number falls inside the stated range.
By their numbers in this assay, from the lowest: compounds 2, 4, 3 and 1 (each within the scatter of the next, the first and the last beyond it).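

In this assay, the change to 3,4-dihydroxyphenyl gives a 1.2-fold lower number from compound 3 to compound 4 (0.07 log units; within the scatter), and the added hydroxy gives a 1.4-fold higher number from compound 2 to compound 4 (0.14 log units; within the scatter). Together with the earlier step, this shows that compounds 2, 3 and 4 differ in their aromatic group on a double-bonded chain carbon bound to a double-bonded ring carbon without any listed step among them leaving the scatter. No available evidence accounts for these results. Going by these compounds, whether an amine or a carboxylic acid on this aromatic ring would produce a step beyond the scatter remains open.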